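The source may hold more compounds than are shown below. What is called first, only, known or untested is meant among the compounds shown, and "the series" means these compounds.

Compound 2 `[N-]=[N+]=N[C@@H]1C(n2cc(Cl)c(=O)[nH]c2=O)[Se][C@H](CO)[C@H]1O` has been tested in a functional assay on A549 cells (Homo sapiens) for cytotoxicity, read by sulforhodamine B assay; on this read-out higher numbers stand for weaker inhibition and lower numbers for stronger inhibition. In this assay compound 2 reaches only a limit of the assay, > 100000 nM, not a measured number. Its closest measured neighbour is compound 1 `[N-]=[N+]=N[C@@H]1C(n2cc(F)c(=O)[nH]c2=O)[Se][C@H](CO)[C@H]1O`, which bears fluoro in place of chloro on the same aromatic carbon. In this assay compound 1 likewise gives only a limit, > 100000 nM. The size of the step that the two limits leave unreadable from compound 1 to compound 2 therefore cannot be read, since both values sit at the limit of > 100000 nM in this assay, at which 2 of the 2 values shown sit. Compound 3 `[N-]=[N+]=N[C@@H]1C(n2cc(I)c(=O)[nH]c2=O)[Se][C@H](CO)[C@H]1O` has not yet been measured in this assay; it differs from compound 2 by iodo in place of chloro on an aromatic carbon. Going by the values given here, the only measured step bearing on this kind of halogen exchange left both ends at the limit, so no shift beyond the scatter can be read from it. For compound 3 the expected step is accordingly a step that the limit leaves unreadable from compound 2 to compound 3, without a readable direction. Compound 3 is estimated to give 150000 nM, within a range from 50000 nM to 500000 nM, most likely again reported as a limit rather than a number.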

Compound 3, half-maximal inhibitory concentration: > 100000 nM
Compound 3: only a limit was reported; the forecaster's own chance of this, stated with the estimate: 85%; the middle value is on the limit's open side.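

Going by these compounds alone, compound 3 also gives only a limit in this assay, so no step among compound 1, compound 2 and compound 3 can be read: the limit of > 100000 nM in this assay, at which 3 of the 3 values shown sit.

Still open is how strongly any of these compounds acts on the cells, and whether exchanging fluoro, chloro and iodo changes that at all.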